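The source may report more compounds than this note shows. Statements on the series, on what has been measured and on what is new or still open speak of the compounds shown alone.

Working notes on the series in an assay on cells (Endothelial cell) for binding affinity to Endothelin-1 receptor (Sus scrofa); a lower number here means a stronger inhibitor, a higher number a weaker inhibitor.

Compound 3 `Cc1ccc(-c2c(NS(=O)(=O)c3ccc(C(F)(F)F)cc3)ncnc2OCCOc2ncc(Br)cn2)cc1` gives 1.4 nM. Compound 2 `Cc1ccc(-c2c(NS(=O)(=O)c3ccc(I)cc3)ncnc2OCCOc2ncc(Br)cn2)cc1` gives 1 nM, and a 1.4-fold higher number from compound 2 to compound 3 (0.15 log units; within the scatter). Compound 1 `CCC(C)(C)c1ccc(S(=O)(=O)Nc2ncnc(OCCOc3ncc(Br)cn3)c2-c2ccc(C)cc2)cc1` is reported only as a limit, < 0.001 nM, at the lower end of the range (the limit of < 0.001 nM in this assay, at which 1 of the 3 values shown sits). So compound 3 sits with compound 2, and both stand well apart from compound 1.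

The step to compound 4 `Cc1ccc(-c2c(NS(=O)(=O)c3cccs3)ncnc2OCCOc2ncc(Br)cn2)cc1` is thiophen-2-yl in place of 4-(trifluoromethyl)phenyl on a sulfonyl sulfur. Going by the values given here, the steps that bear on the group on the sulfonyl sulfur are an at least 1000-fold higher number from compound 1 to compound 2 (3.00 log units; beyond the scatter) and an at least 1400-fold higher number from compound 1 to compound 3 (3.14 log units; beyond the scatter), both large; the swap iodo to trifluoromethyl, a 1.4-fold higher number from compound 2 to compound 3 (0.15 log units; within the scatter), is small. Thiophen-2-yl carries none of these groups, so compound 4 is expected to move away from compound 1 rather than toward it, by a 4.3-fold higher number from compound 3 to compound 4 (0.63 log units; beyond the scatter). Compound 4 is thus estimated at 6 nM, between 1.5 nM and 30 nM.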

Compound 4, half-maximal inhibitory concentration: 3.1 nM
Compound 4: middle estimate off by 1.9-fold (0.29 log units), on the high side; the range from low to high includes it.
By their numbers in this assay, from the lowest: compounds 2 and 3 (each within the scatter of the next); then compound 4. At a limit, below all of these: compound 1.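

Thiophen-2-yl on the sulfonyl sulfur keeps binding close to that of the substituted phenyl groups, with only modest losses: a 2.2-fold higher number from compound 3 to compound 4 (0.35 log units; beyond the scatter) and a 3.1-fold higher number from compound 2 to compound 4 (0.49 log units; beyond the scatter). A five-membered aromatic ring with a hetero atom is therefore tolerated at this position, although the gap to the bulkier alkylphenyl compound remains wide, an at least 3100-fold higher number from compound 1 to compound 4 (3.49 log units; beyond the scatter). That gap has only a lower bound, since compound 1 is reported as a limit: the limit of < 0.001 nM in this assay, at which 1 of the 4 values shown sits.

Open, from the compounds shown here alone, is how an amine or a carboxylic acid on the group at the sulfonyl sulfur would fare. Also open, going by these compounds, is whether a saturated ring such as cyclohexyl would be accepted there.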